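The compounds below may be only part of what the source reports. "The series", "measured", "known", "first", "only" and "open" are said of these compounds alone.

Compound 1 `COC(=O)c1cc(Cl)ccc1OC(=O)COc1cc(O)c2c(=O)cc(-c3ccccc3)oc2c1` was tested in an ADME assay on cells (T-cell, Mus musculus, strain BALB/c) for cytotoxicity, read by MTT assay, with a stated time of 48 h; on this read-out higher numbers stand for lower toxicity in this test and lower numbers for higher toxicity in this test. In this assay compound 1 gives only a limit of the assay, > 436000 nM, so where it stands is known only as that limit. Two companions were measured beside it: compound 2 `COC(=O)c1c(Br)cc(Br)cc1OC(=O)COc1cc(O)c2c(=O)cc(-c3ccccc3)oc2c1` gives 398000 nM in this assay, and compound 3 `COC(=O)c1cccc(OC)c1OC(=O)COc1cc(O)c2c(=O)cc(-c3ccccc3)oc2c1` gives 196000 nM. Compound 4 `COC(=O)c1ccc(Cl)cc1OC(=O)COc1cc(O)c2c(=O)cc(-c3ccccc3)oc2c1` is not yet measured. It differs from compound 1 in one place: 5-chloro-2-(methoxycarbonyl)phenyl in place of 4-chloro-2-(methoxycarbonyl)phenyl on an oxygen next to a carbonyl group. For the measured compounds named here, no measured pair differing in a single place is at hand, so no step size can be read from data; what is known is that compound 1 sits at the limit of > 436000 nM in this assay, at which 1 of the 3 values shown sits. In this assay the step from compound 1 is expected to be small, within the scatter, at an at least 1.0-fold lower number from compound 1 to compound 4 (0.03 log units; that floor lies within the scatter). Compound 4 is therefore expected to give about 400000 nM, between 150000 nM and 900000 nM.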

Compound 4, half-maximal cytotoxic concentration: 265000 nM
Compound 4: middle estimate off by 1.5-fold (0.18 log units), on the high side; low and high end bracket the measured number.
By their numbers in this assay, from the lowest: compounds 3, 4 and 2 (each within the scatter of the next, the first and the last beyond it). At a limit, above all of these: compound 1.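

In this assay, for the compounds shown here, 5-chloro-2-(methoxycarbonyl)phenyl in place of 4-chloro-2-(methoxycarbonyl)phenyl gives the only step at hand between compounds that differ in one place, an at least 1.6-fold lower number from compound 1 to compound 4 (0.21 log units; that floor lies within the scatter). Only a floor can be given for this step, so moving the chlorine may matter more than the scatter, but the data cannot settle this. Compound 1 gives a limit and not a number: the limit of > 436000 nM in this assay, at which 1 of the 4 values shown sits.

The compounds shown leave open how an amine or a carboxylic acid in place of the chlorine would read in this assay. They also leave open what a longer ester chain in place of the methoxycarbonyl would do.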